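Replacing a side group on a short-lived compound

The source may report more compounds than this note shows. Statements on the series, on what has been measured and on what is new or still open speak of the compounds shown alone.

Compound 1 `CC(C)C(CC1C(=O)NC(=O)N1C)c1ccc(-c2ccc3cccc(F)c3c2)[nH]c1=O` gives 0.153 h
Compound 2 `Cc1cc(C(/C=C2\OC(=O)NC2=O)C(C)C)c(=O)[nH]c1-c1ccc2cccc(F)c2c1` gives > 3 h (a limit of the assay)
Compound 3 `CCC(/C=C1\OC(=O)NC1=O)(CC)c1ccc(-c2ccc3cccc(F)c3c2)[nH]c1=O` gives 0.948 h

In an ADME assay on microsomes from liver (Homo sapiens) for metabolic stability (on this read-out higher numbers stand for a longer-lived compound and lower numbers for a shorter-lived compound), compound 1, at 0.153 h, holds the lower of the two actual numbers. Compound 3 gives 0.948 h, a higher number and a gap beyond the usual scatter. Compound 2 reports only a limit of the assay, > 3 h, and not a number.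

Compound 4 `CC(C)C(c1ccc(-c2ccc3cccc(F)c3c2)[nH]c1=O)C1SC(=O)NC1=O` keeps the core of compound 1 but has 2,4-dioxo-1,3-thiazolidin-5-yl in place of (3-methyl-2,5-dioxoimidazolidin-4-yl)methyl, on a saturated chain carbon bound to an aromatic carbon and a saturated chain carbon (2,4-dioxo-1,3-thiazolidin-5-yl in place of (3-methyl-2,5-dioxoimidazolidin-4-yl)methyl on a saturated chain carbon bound to an aromatic carbon and a saturated chain carbon). For the measured compounds named here, no measured pair of compounds differs in just one place, so this change has no direct precedent. Compound 1 starts low at 0.153 h, and compound 3, with a different group on its chain, reaches 0.948 h, which leaves room for a rise. The expected change is a moderate increase beyond the scatter, a 3.9-fold higher number from compound 1 to compound 4 (0.59 log units; beyond the scatter), with wide uncertainty. Compound 4 is estimated at 0.6 h (expected range 0.2 h to 2 h).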

Compound 4, half-life: 1.87 h
Compound 4: the middle estimate sits 3.1-fold (0.49 log units) below what was measured, and the stated range covers the measured number.
By their numbers in this assay, from the lowest: compound 1; then compounds 3 and 4 (each within the scatter of the next). At a limit, above all of these: compound 2.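

For the compounds shown here, this is the only direct reading of a single change: in this assay, putting 2,4-dioxo-1,3-thiazolidin-5-yl in place of (3-methyl-2,5-dioxoimidazolidin-4-yl)methyl on a saturated chain carbon bound to an aromatic carbon and a saturated chain carbon gives a 12-fold higher number from compound 1 to compound 4 (1.09 log units; beyond the scatter). The half-life at this place therefore depends strongly on the group attached, even though each group holds a five-membered non-aromatic ring with 2 hetero atoms. No measurement shown here bears on the cause of this step.

From the compounds shown here alone, the change replaces the ring atoms, the methyl group and the linking carbon together, so it remains open which of these parts matters. Also open, going by these compounds, is how a carboxylic acid or an amine at this place would behave in this assay.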